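A few compounds are considered here, and "the series" means these few. Any claim that something is new, unique, unknown or untested is made for them only; others in the source may bear on it.

Working notes on the series.

The shared core of compound 1 `Nc1cc(N)c2nc(-c3ccccc3)c(NCc3ccc(Cl)c(Cl)c3)nc2c1` carries two amino groups and a phenyl group, and in a functional assay on RPMI8266 cells (Homo sapiens) for inhibition, read by sulforhodamine B assay, with a stated time of 48 h (on this read-out lower numbers stand for stronger inhibition of growth and higher numbers for weaker inhibition of growth), compound 1 gives 3720 nM. Compound 2 `CCOC(=O)[C@H](CCC(=O)O)NC(=O)c1ccc(Sc2nc3cc(N)cc(N)c3nc2-c2ccccc2)cc1` is reported in this assay only as a limit of the assay, < 100000 nM, not as a number (the limit of < 100000 nM in this assay, at which 1 of the 3 values shown sits). Compound 3 `Nc1cc(N)c2nc(-c3ccccc3)c(Oc3ccc(F)cc3)nc2c1` has the highest of the two numbers on the core: in this assay compound 3 gives 46800 nM, and its nearest neighbour, compound 1, sits at a clearly lower number, a gap beyond the usual scatter.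

The next step goes from compound 3 to compound 4 `COc1ccc(Sc2nc3cc(N)cc(N)c3nc2-c2ccccc2)cc1`, which differs at one place: (4-methoxyphenyl)sulfanyl in place of 4-fluorophenoxy on an aromatic carbon. Among the compounds with values here, no pair of measured compounds covers this change directly, so its size is unknown; the only sulfanyl-linked compound on the core, compound 2, reaches a limit rather than a number. The expectation is for no gain, with a step of a 1.2-fold higher number from compound 3 to compound 4 (0.07 log units; within the scatter) that is estimated as small or weakening. Compound 4 is therefore expected at about 55000 nM, in the range 15000 nM to 100000 nM.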

Compound 4, concentration for total growth inhibition: 85100 nM
Compound 4: middle estimate off by 1.5-fold (0.19 log units), on the low side; low and high end bracket the measured number.
By their numbers in this assay, from the lowest: compound 1; then compounds 3 and 4 (each within the scatter of the next).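

In this assay, (4-methoxyphenyl)sulfanyl in place of 4-fluorophenoxy on this aromatic carbon gives a 1.8-fold higher number from compound 3 to compound 4 (0.26 log units; within the scatter), so the two groups cannot be told apart at this position and the exchange brings no gain. Within the data shown here, compound 2 is reported only as a limit of the assay, < 100000 nM, which leaves compound 4 as the first sulfanyl-linked compound on the shared core with an actual number. Nothing in the available data accounts for the size of this step.

The step changes the linking atom and the ring substituent together, so a (4-fluorophenyl)sulfanyl or 4-methoxyphenoxy group would be needed to separate the two. On these data alone, it also remains open whether a 4-methoxybenzylamino or 4-fluorobenzylamino group at this position would come closer to compound 1, at 3720 nM.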